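This account rests on a few compounds, and the source may have more. Where it says the series, first, only, none or still open, it means among the compounds named here.

Measured in a functional assay on MCF7 cells (Homo sapiens) for antiproliferative activity, read by MTT assay, with a stated time of 72 h; a lower number here means a stronger inhibitor, a higher number a weaker inhibitor:

- Compound 1 `O=C(N/N=C/c1cccc(Br)c1)Nc1ccc(Oc2ccnc3[nH]ccc23)c(F)c1`: 49 nM
- Compound 2 `O=C(N/N=C/c1ccc(Cl)c(Cl)c1)Nc1ccc(Oc2ccnc3[nH]ccc23)c(F)c1`: 998 nM
- Compound 3 `O=C(N/N=C/c1ccc(O)cc1)Nc1ccc(Oc2ccnc3[nH]ccc23)c(F)c1`: "not active" (no number reported)

Compound 3 has no number at all. It was reported only as "not active" (no number reported), so it cannot be placed on the scale beside the other two compounds, and any step away from it has no measured starting point.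

Compound 4 `COc1ccc(/C=N/NC(=O)Nc2ccc(Oc3ccnc4[nH]ccc34)c(F)c2)cc1` keeps the whole of compound 3 except for one small change: methyl in place of hydrogen on an oxygen on an aromatic ring. In other words, hydroxy becomes methoxy, turning 4-hydroxyphenyl into 4-methoxyphenyl.

Going by the values given here, no measured step describes this change directly. The nearest evidence is a 20-fold higher number from compound 1 to compound 2 (1.31 log units; beyond the scatter), a large step that also comes from changing only the groups on this aromatic ring. It shows that such a change can move the result in this assay a long way, but it says nothing about a methyl on an oxygen. The size of the step from compound 3 therefore cannot be stated. The expected direction is towards activity that can be measured, though probably weak activity, and another report without a number remains quite possible.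

Compound 4 is expected at about 1500 nM, with an estimated range from 150 nM to 10000 nM.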

Compound 4, half-maximal inhibitory concentration: 5750 nM
Compound 4: the middle estimate sits 3.8-fold (0.58 log units) below what was measured; low and high end bracket the measured number.
By their numbers in this assay, from the lowest: compound 1; then compound 2; then compound 4.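

In this assay, adding a methyl to the oxygen of compound 3 gives compound 4, which has a measured value of 5750 nM, whereas compound 3 was reported only as "not active", so 4-methoxyphenyl can be placed on the scale but the size of the change from 4-hydroxyphenyl cannot be read. The new value also shows that a ring with a single oxygen-linked group can be measured here, yet it sits well up the scale, with a modest step of a 5.8-fold higher number from compound 2 to compound 4 (0.76 log units; beyond the scatter) and a much larger step of a 120-fold higher number from compound 1 to compound 4 (2.07 log units; beyond the scatter) when the halogen-bearing rings are replaced by 4-methoxyphenyl. Nothing shown here gives a measured reason for these differences.

From the compounds shown here alone, it remains open whether a longer chain on this oxygen, such as ethyl, would lower or raise the number further than methyl does. The effect of an amine in place of the methoxy group on this ring is also unknown, so the shown compounds cover only a narrow range of groups at this position.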